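The source may hold more compounds than are shown below. What is called first, only, known or untested is meant among the compounds shown, and "the series" means these compounds.

Of the compounds shown here, two sharing one core have so far been tested in a functional assay on A549 cells (Homo sapiens) for antiproliferative activity, read by CCK-8 assay, with a stated time of 48 h; on this read-out higher numbers stand for weaker inhibition and lower numbers for stronger inhibition. Compound 1 `CC(C)CSc1n[nH]c(-n2[se]c3ccccc3c2=O)n1` gives 37800 nM in this assay. Compound 2 `CCCCCSc1n[nH]c(-n2[se]c3ccccc3c2=O)n1` gives 21100 nM in this assay, the lowest of the two numbers; its nearest neighbour is compound 1, and the step of a 1.8-fold lower number from compound 1 to compound 2 (0.25 log units; within the scatter) is within the scatter, so no order between the two can be read from it. Compound 3 `CCCSc1n[nH]c(-n2[se]c3ccccc3c2=O)n1` is not yet measured. It differs from compound 2 by hydrogen in place of ethyl on a saturated chain carbon, three bonds along the chain from a sulfur, a shortening of the chain on the sulfur. Within the data shown here, the only measured step, from compound 1 to compound 2, exchanged one chain on that sulfur for another and moved the number by less than the scatter, so a change of chain length at this spot has so far left this assay nearly unchanged. Compound 3 is therefore expected to show a step of a 1.3-fold higher number from compound 2 to compound 3 (0.12 log units; within the scatter) no larger than the scatter. The estimate for compound 3 is 28000 nM, with a range from 12000 nM to 70000 nM.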

Compound 3, half-maximal inhibitory concentration: 45500 nM
For compound 3 the middle estimate is 1.6-fold (0.21 log units) below the measured one; measured number inside the range.
By their numbers in this assay, from the lowest: compounds 2, 1 and 3 (each within the scatter of the next, the first and the last beyond it).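

In this assay, among these compounds, shortening the chain on the sulfur, with hydrogen in place of ethyl, gives a 2.2-fold higher number from compound 2 to compound 3 (0.33 log units; beyond the scatter) and so yields the first step at this position that passes the scatter, though only modestly. The change of hydrogen in place of methyl on a saturated chain carbon bound to two saturated chain carbons gives a 1.2-fold higher number from compound 1 to compound 3 (0.08 log units; within the scatter) and stays within the scatter, so compound 1 and compound 3 cannot be ordered. Chain length therefore matters here only between the pentyl chain of compound 2 and the propyl chain of compound 3, and compound 1 lies within the scatter of both.

As far as these compounds go, whether a chain longer than pentyl, an amine or a carboxylic acid on the sulfur would move the number further remains open. No other measurement is at hand to account for these steps.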